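Swapping the ring on a sulfonamide nitrogen

The source may report more compounds than this note shows. Statements on the series, on what has been measured and on what is new or still open speak of the compounds shown alone.

Of the compounds shown here, two have been measured in a physicochemical assay for solubility; on this read-out lower numbers stand for lower solubility and higher numbers for higher solubility. Compound 1 `O=S(=O)(Nc1nccs1)c1ccc2c(c1)OCC[C@@H]2c1ccc(C(F)(F)F)cc1N1CCNCC1` gives 288000 nM, while compound 2 `Cn1nccc1-c1cc(C(F)(F)F)ccc1[C@H]1CCOc2cc(S(=O)(=O)Nc3cccc(F)n3)ccc21` gives 27000 nM, the lower of the two numbers and well apart from compound 1, since the gap lies beyond the usual scatter. Compound 3 `Cn1nccc1-c1cc(C(F)(F)F)ccc1[C@H]1CCOc2cc(S(=O)(=O)Nc3cccnn3)ccc21` has not yet been measured in this assay. It differs from compound 2 in one place: pyridazin-3-yl in place of 6-fluoropyridin-2-yl on a sulfonamide nitrogen. Within the data shown here, no measured pair here shows the effect of this particular exchange, so the expectation for compound 3 rests only on the numbers given for compound 2 and compound 1. The step of a 1.9-fold higher number from compound 2 to compound 3 (0.27 log units; within the scatter) is expected to be a small rise, close to the edge of the scatter rather than clearly beyond it. Compound 3 is estimated at 50000 nM in this assay, with a likely range from 15000 nM to 160000 nM.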

Compound 3, solubility: 915000 nM
Compound 3: the middle estimate sits 18-fold (1.26 log units) below what was measured; the whole stated range lies below it.
By their numbers in this assay, from the lowest: compound 2; then compound 1; then compound 3.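

In this assay, pyridazin-3-yl in place of 6-fluoropyridin-2-yl on a sulfonamide nitrogen gives a 34-fold higher number from compound 2 to compound 3 (1.53 log units; beyond the scatter), with the rest of the molecule unchanged. This is the first step shown that isolates this position, and it establishes that exchanging this one ring can move the read-out well beyond the usual scatter. Nothing measured here accounts for the size of the rise.

The compounds shown leave open whether the loss of the fluorine or the second ring nitrogen matters more; a plain pyridin-2-yl on the same sulfonamide nitrogen would help to separate the two. Also open, as far as these compounds go, is whether the same exchange gives a step of similar size on the core of compound 1.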